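A few compounds are considered here, and "the series" means these few. Any claim that something is new, unique, unknown or untested is made for them only; others in the source may bear on it.

In a physicochemical assay for solubility, read by HPLC, using the shake flask method, measured as kinetic solubility, with a stated time of 2 h, at pH 7.4 (on this read-out lower numbers stand for lower solubility and higher numbers for higher solubility), compound 1 `Cc1cc(NCc2ncccn2)n2nc(C)c(-c3ccccc3)c2n1` gives 37900 nM. Compound 2 `Cc1cc(NCc2ccccn2)n2ncc(-c3ccc(F)c(Cl)c3)c2n1` returns only < 5000 nM in this assay, which is a limit of the assay rather than a number. This is the limit of < 5000 nM in this assay, at which 1 of the 2 values shown sits. Compound 3 `Cc1cc(NCc2ccccn2)n2ncc(-c3cncnc3)c2n1` differs from compound 2 by pyrimidin-5-yl in place of 3-chloro-4-fluorophenyl on an aromatic carbon. Going by the values given here, since no measured pair here differs in a single place, the size of this change can only be expected: in this assay the step of an at least 8.0-fold higher number from compound 2 to compound 3 (0.90 log units; beyond the scatter) is expected to raise solubility beyond the usual scatter. Compound 3 is therefore estimated at 40000 nM, with a likely range from 10000 nM to 150000 nM.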

Compound 3, solubility: 111000 nM
The estimate for compound 3 lay 2.8-fold (0.44 log units) below the measured number, within the range that was stated.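

Going by these compounds alone, on this aromatic carbon of the five-membered ring, pyrimidin-5-yl in place of 3-chloro-4-fluorophenyl brings an at least 22-fold higher number from compound 2 to compound 3 (1.34 log units; beyond the scatter) in this assay, so a single group at this place can move the read-out by a large amount, something no earlier pair could show. Compound 2 stands at a limit of the assay, not at a number: the limit of < 5000 nM in this assay, at which 1 of the 3 values shown sits.

The compounds shown do not separate the effect of the ring nitrogens entering from that of the chlorine and fluorine leaving. From the compounds shown here alone, how an amine or a carboxylic acid on this carbon would read also stays open.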